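A few compounds are considered here, and "the series" means these few. Any claim that something is new, unique, unknown or untested is made for them only; others in the source may bear on it.

Compound 1, `Cc1c([C@H](OC(C)(C)C)C(=O)O)c(N2CCC(C)(C)CC2)c(-c2ccc(OCCc3ccc(F)cc3)cc2)c2nccn12`, in an ADME assay on microsomes from liver (Homo sapiens) for metabolic stability (a lower number here means that the compound disappears faster, a higher number that the compound lasts longer), gives > 2 h, which is a limit of the assay.
Compound 2, `Cc1cn2c(C)c([C@H](OC(C)(C)C)C(=O)O)c(N3CCC(C)(C)CC3)c(-c3ccc(OCCc4ccc(F)cc4)cc3)c2n1`, in this assay gives > 2 h, again a limit.
Compound 3, `Cc1c([C@H](OC(C)(C)C)C(=O)O)c(N2CCC(C)(C)CC2)c(-c2ccc(OCCc3ccc(F)cc3)cc2)c2ncnn12`, in this assay gives > 2 h, again a limit.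

From compound 1 to compound 2 the change is methyl in place of hydrogen on an aromatic carbon. Its step, a step that the two limits leave unreadable from compound 1 to compound 2, cannot be read, since both values are limits. Compound 3 differs from compound 1 in the core; that difference is not broken down here. Compound 4, `Cc1nc2c(-c3ccc(OCCc4ccc(F)cc4)cc3)c(N3CCC(C)(C)CC3)c([C@H](OC(C)(C)C)C(=O)O)c(C)n2n1`, has not been measured. It differs from compound 3 by methyl in place of hydrogen on an aromatic carbon, the same kind of change as from compound 1 to compound 2, though here the ring holds 3 nitrogen and the carbon lies between two ring nitrogen atoms, while in compound 2 the ring holds 2 nitrogen and the carbon lies next to the ring nitrogen. The step from compound 3 to compound 4 is expected to be a step that the limit leaves unreadable from compound 3 to compound 4, because of the limit of > 2 h in this assay, at which 3 of the 3 values shown sit. Compound 4 is therefore estimated at 3 h, expected between 1.5 h and 6 h.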

Compound 4, half-life: > 2 h
Compound 4 gave a limit, no number; the forecaster's own chance of this, stated with the estimate: 75%; the middle value does not contradict the limit.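

No step can be read between compound 3 and compound 4, since both results are limits and not numbers: the limit of > 2 h in this assay, at which 4 of the 4 values shown sit.

The compounds shown leave open how long each one actually lasts in this assay, and whether methyl in place of hydrogen on an aromatic carbon changes that at all.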